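The source may hold more compounds than are shown below. What is called first, only, known or untested is meant among the compounds shown, and "the series" means these compounds.

Compound 1, `CCOC(=O)C1=C(C)N/C(=C/c2cc(C)n(-c3ccc(OC)cc3)c2C)C1=O`, in a physicochemical assay for solubility, read by nephelometry, in phosphate buffer, measured as kinetic solubility, at pH 6.5; a lower number here means a less soluble compound, a higher number a more soluble compound: 3.1 ug/mL.
Compound 2, `CCOC(=O)C1=C(C)N/C(=C/c2cc(C)n(-c3cccc(OC)c3)c2C)C1=O`, in this assay: < 1.6 ug/mL, which is a limit of the assay rather than a number.

Compound 2 thus stands at the floor of the assay, as described by the limit of < 1.6 ug/mL in this assay, at which 1 of the 2 values shown sits, so its true solubility is not known beyond that bound. Within the data shown here, the only measured step, an at least 1.9-fold lower number from compound 1 to compound 2 (0.28 log units; that floor lies within the scatter), lies within the scatter and gives no clear direction. Compound 3, `CCOC(=O)C1=C(C)N/C(=C/c2cc(C)n(-c3ccncc3)c2C)C1=O`, differs from compound 2 by pyridin-4-yl in place of 3-methoxyphenyl on an aromatic nitrogen. Among the measured compounds shown here, no measured step exchanges one ring type for another, so the single measured step offers no direct guide to the size or direction of this change. The step expected is an at least 1.8-fold higher number from compound 2 to compound 3 (0.27 log units; that floor lies within the scatter), carried with wide uncertainty. For compound 3 the estimate in this assay is 3 ug/mL, expected to fall between 1.2 ug/mL and 10 ug/mL.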

Compound 3, solubility: 50 ug/mL
Beside the measured number, compound 3's estimate is 17-fold (1.22 log units) below it; the whole stated range lies below it.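

This position on the aromatic nitrogen now shows a clear direction in this assay: pyridin-4-yl in place of 3-methoxyphenyl gives an at least 31-fold higher number from compound 2 to compound 3 (1.49 log units; beyond the scatter), and pyridin-4-yl in place of 4-methoxyphenyl gives a 16-fold higher number from compound 1 to compound 3 (1.21 log units; beyond the scatter). Both steps lie beyond the usual scatter, whereas the step between compound 1 and compound 2 did not, so among these three compounds the exchange of ring type counts for far more than the shift of the methoxy group. The first step gives only a lower bound on the size, as the number for compound 2 is a limit of the assay: the limit of < 1.6 ug/mL in this assay, at which 1 of the 3 values shown sits.

These compounds do not separate the ring nitrogen of pyridin-4-yl from the loss of the methoxy group, which a plain phenyl ring would do. On these data alone, whether an amine or a carboxylic acid on the ring would go the same way also stays open.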